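Swapping Phenyl for Pyridin-4-yl on a Different Core

A few compounds are considered here, and "the series" means these few. Any claim that something is new, unique, unknown or untested is made for them only; others in the source may bear on it.

Compound 1 `CCNS(=O)(=O)c1ccc(NC2CC3CCC2C3)c(NCc2ccccc2)c1` serves as the reference here. In a functional assay (IMR-32 cells, Homo sapiens) for inhibition, read by fluorescence, with stated times of 1 h and 13 h (a lower number here means a stronger inhibitor, a higher number a weaker inhibitor), compound 1 gives 3 nM. Compound 2 `CCNS(=O)(=O)c1ccc(NC2CC3CCC2C3)c(NCc2ccncc2)c1` carries one change relative to it: pyridin-4-yl in place of phenyl on a saturated chain carbon bound to a nitrogen on an aromatic ring. In this assay compound 2 gives 9.4 nM, which is a 3.1-fold higher number from compound 1 to compound 2 (0.50 log units; beyond the scatter). Compound 3 `CCNS(=O)(=O)c1ccc(NC2CCCCCCC2)c(NCc2ccccc2)c1` differs from compound 1 only in its core, and how the two cores differ is a group of 8 heavy atoms (8 carbon; one eight-membered non-aromatic ring of carbon only) in place of a group of 7 heavy atoms (7 carbon; 2 five-membered non-aromatic rings of carbon only), on a nitrogen on an aromatic ring. In this assay compound 3 gives 2.4 nM, and the step of a 1.3-fold lower number from compound 1 to compound 3 (0.10 log units; within the scatter) lies within the scatter, so compounds 1 and 3 behave alike on this read-out. Compound 4 `CCNS(=O)(=O)c1ccc(NC2CCCCCCC2)c(NCc2ccncc2)c1` has not yet been measured. It stands to compound 3 as compound 2 stands to compound 1: pyridin-4-yl in place of phenyl on a saturated chain carbon bound to a nitrogen on an aromatic ring. The place of the change is described in the same words for both pairs, so this is the same kind of change carried onto the other core. Because the earlier step was a 3.1-fold higher number from compound 1 to compound 2 (0.50 log units; beyond the scatter), a step of similar size is expected here, namely a 3.1-fold higher number from compound 3 to compound 4 (0.49 log units; beyond the scatter). Compound 4 is therefore expected to give about 7.5 nM, most likely between 3.5 nM and 16 nM.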

Compound 4, half-maximal inhibitory concentration: 22 nM
Estimate against measurement, compound 4: 2.9-fold (0.47 log units) below; measured number above the stated range.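

In this assay, pyridin-4-yl in place of phenyl again gives a higher number, a 9.2-fold higher number from compound 3 to compound 4 (0.96 log units; beyond the scatter), so the direction of the change carries over to the second core, but its size does not: the same change on two cores in this assay, a 3.1-fold higher number (0.50 log units; beyond the scatter) from compound 1 to compound 2 and a 9.2-fold higher number (0.96 log units; beyond the scatter) from compound 3 to compound 4, 2.9-fold (0.47 log units) apart, beyond the scatter of two such steps

Seen from the other side, the change of core made no difference beyond the scatter while phenyl was present, yet with pyridin-4-yl it gives a 2.3-fold higher number from compound 2 to compound 4 (0.37 log units; beyond the scatter), so the two changes do not act independently in these four compounds: the same change on two cores in this assay, a 1.3-fold lower number (0.10 log units; within the scatter) from compound 1 to compound 3 and a 2.3-fold higher number (0.37 log units; beyond the scatter) from compound 2 to compound 4, 2.9-fold (0.47 log units) apart, beyond the scatter of two such steps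

This shows that, within this small set, a step measured on one core predicted the direction on the other but not the size; it does not show why the steps differ, or whether the same direction would hold on a third core.

The compounds shown leave open how another ring in place of phenyl, such as thiophene or pyrimidine, would behave on these two cores. They also leave open whether a cyclohexyl group on the nitrogen on the aromatic ring would give a small or a large step for the same change.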